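Extending the chain on a cyclic sulfoxide thioimidate

The compounds below may be only part of what the source reports. "The series", "measured", "known", "first", "only" and "open" are said of these compounds alone.

Of the compounds shown here, two have been tested in a functional assay (aorta) for inhibition, with Rattus norvegicus as the target; a lower number here means a stronger inhibitor, a higher number a weaker inhibitor. Compound 1 `C/N=C(\S)[C@]1(c2ccccn2)CCCC[S+]1[O-]` gives only a limit in this assay, > 30000 nM, and not a number. Compound 2 `CCC/N=C(\S)[C@]1(c2cccnc2)CCCC[S+]1[O-]` is the one compound with a measured value: in this assay compound 2 gives 600 nM, the only number shown. The entry for compound 1 sits at a limit (the limit of > 30000 nM in this assay, at which 1 of the 2 values shown sits). Compound 3 `COC(=O)CC/N=C(\S)[C@]1(c2cccnc2)CCCC[S+]1[O-]` has not yet been measured; it differs from compound 2 by methoxycarbonyl in place of methyl on a saturated chain carbon, two bonds along the chain from a double-bonded nitrogen. Within the data shown here, no pair of measured compounds differs in just one place, so no measured step shows how this assay responds to such a change. For this change the expectation is a small step, if any, perhaps toward weaker inhibition and possibly within the usual scatter, so that the step from compound 2 to compound 3 is estimated as a 1.7-fold higher number from compound 2 to compound 3 (0.22 log units; within the scatter). In this assay compound 3 is therefore expected to give about 1000 nM, with a range from 200 nM to 5000 nM.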

Compound 3, concentration for 90% inhibition: > 30000 nM
Compound 3: no number, only a limit (the forecaster's own chance of this, stated with the estimate: 10%); at least 30-fold (1.47 log units) between middle value and limit.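

Swapping methyl for methoxycarbonyl on a saturated chain carbon, two bonds along the chain from a double-bonded nitrogen, gives an at least 50-fold higher number from compound 2 to compound 3 (1.69 log units; beyond the scatter) in this assay. Among these compounds, this is the first single-place change that can be read here, and it shows that inhibition in this assay does not tolerate every group at this position. Compound 3 gives only a limit and not a number, > 30000 nM, so the full size of the step stays unknown: the limit of > 30000 nM in this assay, at which 2 of the 3 values shown sit.

The compounds shown leave open whether the loss comes with the ester itself or with any larger group at this place. From the compounds shown here alone, a plain butyl chain or a carboxylic acid here would help to tell these apart, and whether any group can give a lower number than compound 2 also remains open.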